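Removing the bromine from compound 2

The source may hold more compounds than are shown below. What is called first, only, known or untested is meant among the compounds shown, and "the series" means these compounds.

Compound 1 `Cc1ccc2c(c1)/C(=c1/sc(=Cc3ccc(C=O)c(C=O)c3)c(=O)n1CCN(C)C)C(=O)N2`: 1030 nM
Compound 2 `CCN(CC)CCCn1c(=O)c(=Cc2ccccc2O)s/c1=C1\C(=O)Nc2ccc(Br)cc21`: 18100 nM
Compound 3 `CN(C)CCn1c(=O)c(=Cc2ccc(F)c(F)c2)s/c1=C1\C(=O)Nc2ccc(F)cc21`: 3090 nM

In a functional assay on HT-29 cells (Homo sapiens) for inhibition, read by MTT assay, with a stated time of 72 h (a lower number here means a stronger inhibitor, a higher number a weaker inhibitor), compound 2 gives 18100 nM, the highest of the three numbers. Compound 3 lies nearest to it and compound 1 furthest, and both gaps are beyond the scatter, so compound 2 is the weakest inhibitor of the three. Compound 4 `CCN(CC)CCCn1c(=O)c(=Cc2ccccc2O)s/c1=C1\C(=O)Nc2ccccc21` differs from compound 2 in one place: hydrogen in place of bromo on an aromatic carbon. Among the measured compounds shown here, no measured pair shows this exact change, so the size of the step in this assay is uncertain; a step of modest size, in either direction and possibly within the scatter, is expected. For compound 4 the expected value is 22000 nM, with a range from 7000 nM to 70000 nM, corresponding to an expected step of a 1.2-fold higher number from compound 2 to compound 4 (0.08 log units; within the scatter).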

Compound 4, half-maximal inhibitory concentration: > 200000 nM
Compound 4 ended at the assay's limit; the forecaster's own chance of this, stated with the estimate: 20%; middle value at least 9.0-fold (0.95 log units) away from the limit.
By their numbers in this assay, from the lowest: compound 1; then compound 3; then compound 2. At a limit, above all of these: compound 4.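

On this aromatic carbon, hydrogen in place of bromo gives an at least 11-fold higher number from compound 2 to compound 4 (1.04 log units; beyond the scatter), so in this assay this position is far from indifferent to the change, and bromo is tied to the measurable inhibition of compound 2. For compound 4, > 200000 nM is a limit of the assay and not a number. The step therefore gives only a minimum size: the limit of > 200000 nM in this assay, at which 1 of the 4 values shown sits.

The compounds shown leave open whether a chloro or a methoxy group on this carbon would keep the inhibition seen with bromo. They also leave open whether the same step holds with a different chain on the ring nitrogen.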